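A few compounds are considered here, and "the series" means these few. Any claim that something is new, unique, unknown or untested is made for them only; others in the source may bear on it.

Compound 1 `COc1ccc(/C=C2\CN(C(=S)SCc3cn(Cc4ccc(F)cc4)nn3)C/C(=C\c3ccc(OC)cc3)C2=O)cc1` and compound 2 `Cc1ccc(/C=C2\CN(C(=S)SCc3cn(Cc4ccc(F)cc4)nn3)C/C(=C\c3ccc(C)cc3)C2=O)cc1` are built on cores that differ in more than a single spot, and the difference between the two cores is not broken down here. Compound 3 `Cc1ccc(/C=C2\CN(C(=S)SCc3cn(Cc4cccc(Cl)c4)nn3)C/C(=C\c3ccc(C)cc3)C2=O)cc1` is compound 2 with 3-chlorophenyl in place of 4-fluorophenyl on a saturated chain carbon bound to an aromatic nitrogen. Compound 4 `COc1ccc(/C=C2\CN(C(=S)SCc3cn(Cc4cccc(Cl)c4)nn3)C/C(=C\c3ccc(OC)cc3)C2=O)cc1`, which has not yet been tested, is compound 1 with exactly the same change, (3-chlorophenyl in place of 4-fluorophenyl on a saturated chain carbon bound to an aromatic nitrogen), made at a place described in the same words.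

In a functional assay on MDA-MB-231 cells (Homo sapiens) for cytotoxicity, read by MTT assay, with a stated time of 24 h (a higher number here means a weaker inhibitor, a lower number a stronger inhibitor), compound 2 gives 45600 nM and compound 3 gives 83000 nM, so the change produced a 1.8-fold higher number from compound 2 to compound 3 (0.26 log units; within the scatter). For compound 1 the assay reports no number but only a limit, > 100000 nM, which is the limit of > 100000 nM in this assay, at which 1 of the 3 values shown sits.

The same change is expected to move compound 4 by about a step that the limit leaves unreadable from compound 1 to compound 4 in this assay, resting on compound 3 having reached 83000 nM from compound 2. Compound 4 is therefore estimated at 180000 nM, somewhere between 80000 nM and 400000 nM, and is more likely than not to be reported again only as a limit.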

Compound 4, half-maximal inhibitory concentration: 32000 nM
For compound 4 the middle estimate is 5.6-fold (0.75 log units) above the measured one, and the stated range ends above it.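

Compound 1 is known only as a limit, > 100000 nM. Even so, in this assay replacing the 4-fluorobenzyl group with 3-chlorobenzyl on the core of compound 1 gives an at least 3.1-fold lower number from compound 1 to compound 4 (0.49 log units; beyond the scatter), so the change does not carry over unchanged from one core to the other: the same change on two cores in this assay, a 1.8-fold higher number (0.26 log units; within the scatter) from compound 2 to compound 3 and an at least 3.1-fold lower number (0.49 log units; beyond the scatter) from compound 1 to compound 4, at least 5.6-fold (0.75 log units) apart, beyond the scatter of two such steps. For the compounds shown here, with only one pair on each core, these results do not show why the two cores part ways, nor how the same change would behave on a third core.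

Still open, going by these compounds, is whether the change would follow either pattern on a core with ethoxy groups in place of the methoxy groups of compound 1. Also open, on these data alone, is how a plain benzyl group, with neither fluorine nor chlorine, would read on these cores.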